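A few compounds are considered here, and "the series" means these few. Any claim that something is new, unique, unknown or untested is made for them only; others in the source may bear on it.

The measured compounds:
Compound 1 `CC(=O)Nc1ccc(Nc2nccc(-c3cccnc3)n2)cc1` gives 3600 nM in a functional assay for inhibition, with Homo sapiens as the target; a lower number here means a stronger inhibitor, a higher number a weaker inhibitor.
Compound 2 `COc1cccc(Nc2nccc(-c3cc4ccccc4o3)n2)c1` gives 2800 nM in this assay.
Compound 3 `CC(=O)Nc1ccc(Nc2nccc(-c3ccccn3)n2)cc1` gives 1500 nM in this assay.

Among these three numbers compound 1 has the highest. Its value and that of compound 2 lie within the scatter of each other, whereas a 2.4-fold lower number from compound 1 to compound 3 (0.38 log units; beyond the scatter).

Compound 4 `CCOC(=O)c1ccc(Nc2nccc(-c3cccnc3)n2)cc1` differs from compound 1 in one place: ethoxycarbonyl in place of acetamido on an aromatic carbon. For the measured compounds named here, the single measured step exchanges one pyridyl group for another and leaves the acetamido group untouched, so it does not bear on this change. Going by the values given here, no measured step speaks to replacing the acetamido group, and the expectation for compound 4 therefore rests on compound 1 alone, with a wide range. Compound 4 is expected to give 4000 nM in this assay, between 1300 nM and 12000 nM. The expected step of a 1.1-fold higher number from compound 1 to compound 4 (0.05 log units; within the scatter) is not anticipated to exceed the scatter.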

Compound 4, half-maximal inhibitory concentration: 12400 nM
Compound 4: middle estimate off by 3.1-fold (0.49 log units), on the low side; the whole stated range lies below it.
By their numbers in this assay, from the lowest: compounds 3, 2 and 1 (each within the scatter of the next, the first and the last beyond it); then compound 4.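

For the compounds shown here, on this aromatic carbon, para to a large group, the substituent itself affects the result: ethoxycarbonyl in place of acetamido gives a 3.4-fold higher number from compound 1 to compound 4 (0.54 log units; beyond the scatter) in this assay, the first measured change of this group. The swap goes from 1 hydrogen-bond donor to 0 and from 4 heavy atoms to 5, but nothing measured here explains the rise. Still open, as far as these compounds go, is whether a carboxylic acid or an amine on this carbon would give a number closer to that of acetamido or ethoxycarbonyl. Also open, from the compounds shown here alone, is whether the same swap gives a similar step with the pyridin-2-yl group of compound 3.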